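Sulfonamide substituent swap at an assay limit

A few compounds are considered here, and "the series" means these few. Any claim that something is new, unique, unknown or untested is made for them only; others in the source may bear on it.

Values in a physicochemical assay for acid dissociation, each one a limit and not a number:
- compound 1 `O=C1C(Cl)=C(Nc2ccc(S(=O)(=O)Nc3cnn(-c4ccccc4)c3)cc2)C(=O)c2ccccc21` gives < 7.91
- compound 2 `Cc1cc(NS(=O)(=O)c2ccc(NC3=C(Cl)C(=O)c4ccccc4C3=O)cc2)no1` gives < 7.91
- compound 3 `Cc1noc(NS(=O)(=O)c2ccc(NC3=C(Cl)C(=O)c4ccccc4C3=O)cc2)c1C` gives < 7.91

Among the measured compounds shown here, compound 2 stands only at a limit, < 7.91, and no measured compound has a number: the limit of < 7.91 in this assay, at which 3 of the 3 values shown sit.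

Compound 4 `Cc1nnc(NS(=O)(=O)c2ccc(NC3=C(Cl)C(=O)c4ccccc4C3=O)cc2)s1` differs from compound 2 at one place: 5-methyl-1,3,4-thiadiazol-2-yl in place of 5-methyl-1,2-oxazol-3-yl on a sulfonamide nitrogen. Two measured steps change the same sulfonamide substituent: a step that the two limits leave unreadable from compound 1 to compound 2 and a step that the two limits leave unreadable from compound 2 to compound 3. Neither offers a size or direction to carry over, so no readable change is expected in this assay. As a rough number, the expected step is a step that the limit leaves unreadable from compound 2 to compound 4. Compound 4 is estimated at 7.4, with an expected range of 6.4 to 7.9, and another limit is likely.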

Compound 4, acid dissociation constant: < 7.91
Compound 4 gave a limit, no number; the forecaster's own chance of this, stated with the estimate: 85%; the middle value is on the limit's open side.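

No step among compound 1, compound 2, compound 3 and compound 4 can be read in this assay, as each value is a limit: the limit of < 7.91 in this assay, at which 4 of the 4 values shown sit.

The compounds shown leave open the size and direction of any change with the sulfonamide substituent.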